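A few compounds are considered here, and "the series" means these few. Any claim that something is new, unique, unknown or untested is made for them only; others in the source may bear on it.

The three measured compounds share one core and differ only in the group carried on an aromatic nitrogen of the five-membered ring with three nitrogen. Compound 1 `CCOC(=O)C1=Cc2ccccc2OC1(OCc1cn(CC(=O)Nc2ccc(OC)cc2)nn1)C(F)(F)F` carries a ((4-methoxyphenyl)carbamoyl)methyl group there, and in a functional assay on HeLa cells (Homo sapiens) for inhibition, read by MTT assay, with a stated time of 24 h (on this read-out lower numbers stand for stronger inhibition and higher numbers for weaker inhibition), compound 1 gives 31900 nM. Compound 2 `CCOC(=O)C1=Cc2ccccc2OC1(OCc1cn(CC(=O)Nc2ccccc2Br)nn1)C(F)(F)F` carries the ((2-bromophenyl)carbamoyl)methyl group instead. In this assay compound 2 returns only a limit of the assay, > 150000 nM; this reading is the limit of > 150000 nM in this assay, at which 1 of the 3 values shown sits. The change is an at least 4.7-fold higher number from compound 1 to compound 2 (0.67 log units; beyond the scatter). Compound 3 `CCOC(=O)C1=Cc2ccccc2OC1(OCc1cn(-c2ccc(F)c([N+](=O)[O-])c2)nn1)C(F)(F)F` places a 4-fluoro-3-nitrophenyl directly on the aromatic nitrogen, and in this assay compound 3 gives 15600 nM, the lowest of the two numbers shown; the steps are a 2.0-fold lower number from compound 1 to compound 3 (0.31 log units; beyond the scatter) and an at least 9.6-fold lower number from compound 2 to compound 3 (0.98 log units; beyond the scatter). Compound 4 `CCOC(=O)C1=Cc2ccccc2OC1(OCc1cn(-c2ccc(C)cc2)nn1)C(F)(F)F` is the next member: 4-methylphenyl in place of 4-fluoro-3-nitrophenyl on an aromatic nitrogen. Among the compounds with values here, no measured step exchanges one aryl for another on this nitrogen, so the two steps into compound 3 only show that a directly attached aryl sits below the amide-bearing groups. Removing the nitro and fluorine is expected to cost some of that gain, and compound 4 is therefore estimated at 28000 nM in this assay, between 8000 nM and 90000 nM, a step of a 1.8-fold higher number from compound 3 to compound 4 (0.25 log units; within the scatter).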

Compound 4, half-maximal inhibitory concentration: 25100 nM
Beside the measured number, compound 4's estimate is 1.1-fold (0.05 log units) above it; low and high end bracket the measured number.
By their numbers in this assay, from the lowest: compounds 3, 4 and 1 (each within the scatter of the next, the first and the last beyond it). At a limit, above all of these: compound 2.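

Within the data shown here, with the 4-methylphenyl, two directly attached aryl groups can be compared on this aromatic nitrogen for the first time, and in this assay the exchange of 4-fluoro-3-nitrophenyl for 4-methylphenyl is a 1.6-fold higher number from compound 3 to compound 4 (0.21 log units; within the scatter), so the two groups are not told apart even though the nitro group and fluorine are gone. Compound 4 also cannot be told apart from the amide-bearing compound 1, at a 1.3-fold lower number from compound 1 to compound 4 (0.10 log units; within the scatter), so it goes against the reading that a directly attached aryl sits clear of the amide-bearing groups, a reading that now rests on compound 3 alone among these two comparisons. Only the step from the 2-bromophenyl amide stays beyond the scatter, at an at least 5.9-fold lower number from compound 2 to compound 4 (0.77 log units; beyond the scatter), and compound 2 gives a limit of the assay rather than a number: the limit of > 150000 nM in this assay, at which 1 of the 4 values shown sits.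

The compounds shown leave open whether an amine or a carboxylic acid on the directly attached aryl, in place of the methyl, would move the number beyond the scatter. They also leave open how an unsubstituted phenyl or a saturated cyclohexyl on the same aromatic nitrogen would compare.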